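The compounds below may be only part of what the source reports. "The series", "measured", "known", "first", "only" and "open" are said of these compounds alone.

Compound 1, with the structure `Cc1ccc(-c2c[nH]nc2S(=O)(=O)CC2=NCCS2)cc1`, was tested in a functional assay, tested at 100 ug/mL (a higher number here means a stronger effect of the compound at the concentration tested, a lower number a weaker effect), and came out as "not active" (no number reported), so no single number stands for it; it can only be placed at the weak end of the series. Two other compounds give the frame. Compound 2, `COc1ccc(C2=NN(c3ccccc3)C(c3ccc(C)cc3)C2S(=O)(=O)CC2=NCCO2)cc1`, reaches 67.7% in this assay, and compound 3, `O=S(=O)(CC1=NCCO1)c1c(-c2ccccc2)nn(-c2ccccc2)c1-c1ccccc1`, reaches 59.1% in this assay. Both carry a different shared core from compound 1 and differ from it in more than one place, so the gap between them and compound 1 cannot be tied to any single change; what can be said is that the two measured numbers lie well above the inactive reading of compound 1.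

The new compound 4, `O=S(=O)(CC1=NCCS1)c1n[nH]cc1-c1ccc(Cl)cc1`, differs from compound 1 in one place: chloro in place of methyl on an aromatic carbon. Put more fully, a 4-methylphenyl becomes a 4-chlorophenyl, the rest of the molecule unchanged. Nothing measured pairs a methyl with a chloro on the same scaffold, so no step size is known. Since compound 1 sits at the inactive floor, the step is expected to be small and within the scatter, in either direction, rather than a jump toward the readings of compound 2 or compound 3. The expected activity of compound 4 in this assay is therefore 15%, estimated within a range from 0% to 45%.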

Compound 4, a percentage reported as activity, at one concentration (the size of the read-out at that concentration, not a potency): "not active" (no number reported)
Compound 4: no number reported, so the estimate cannot be set against anything.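

In this assay, among these compounds, compound 1 gives "not active" (no number reported), and compound 4 gives "not active" (no number reported), so no step from methyl to chloro can be read from this pair. Nothing available offers an explanation for this result. The compounds shown leave open whether any change to the core of compound 1 would yield a measurable reading.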